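Swapping the triazole substituent for a carboxymethyl group

The source may hold more compounds than are shown below. What is called first, only, known or untested is meant among the compounds shown, and "the series" means these compounds.

Measured compounds:
compound 1 `CN(CCNCc1cn(-c2cccc(Cl)c2)nn1)CCNc1ccnc2cc(Cl)ccc12`: 17000 nM
compound 2 `CN(CCNCc1cn(-c2ccc(Br)cc2)nn1)CCNc1ccnc2cc(Cl)ccc12`: 15000 nM
compound 3 `CN(CCNCc1cn(Cc2ccc(Br)cc2)nn1)CCNc1ccnc2cc(Cl)ccc12`: 12000 nM

In a functional assay on NCI-H460 cells (Homo sapiens) for antiproliferative activity, read by sulforhodamine B assay, with a stated time of 72 h (a lower number here means a stronger inhibitor, a higher number a weaker inhibitor), compound 1 gives the highest of the three numbers, with compound 2 nearest and compound 3 furthest, both differing only within the scatter. The step of a 1.1-fold lower number from compound 1 to compound 2 (0.05 log units; within the scatter) and the step of a 1.4-fold lower number from compound 1 to compound 3 (0.15 log units; within the scatter) show that exchanging one halogenated aryl or benzyl group for another on the triazole nitrogen leaves this assay essentially unchanged; the step of a 1.3-fold lower number from compound 2 to compound 3 (0.10 log units; within the scatter) says the same.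

Compound 4 `CN(CCNCc1cn(CC(=O)O)nn1)CCNc1ccnc2cc(Cl)ccc12` differs from compound 1 in one place: carboxymethyl in place of 3-chlorophenyl on an aromatic nitrogen. Going by the values given here, no measured step covers the loss of the aromatic ring altogether in favour of a short acid-bearing chain, so the three measured steps bear on it only indirectly, and they show that this position tolerates small changes without effect. Given that, the step of a 1.5-fold higher number from compound 1 to compound 4 (0.17 log units; within the scatter) is expected to be small to modest, most plausibly toward a higher number, with wide uncertainty. Compound 4 is therefore estimated at 25000 nM in this assay, within the range 8000 nM to 80000 nM.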

Compound 4, half-maximal inhibitory concentration: > 200000 nM
Compound 4: only a limit was reported; the forecaster's own chance of this, stated with the estimate: 20%; at least 8.0-fold (0.90 log units) between middle value and limit.
By their numbers in this assay, from the lowest: compounds 3, 2 and 1 (each within the scatter of the next). At a limit, above all of these: compound 4.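

For compound 4, this assay gives only a limit and not a number: the limit of > 200000 nM in this assay, at which 1 of the 4 values shown sits.

Exchanging the halogenated aryl and benzyl groups among themselves had stayed within the scatter, but carboxymethyl on this aromatic nitrogen is a large step from each of them: an at least 11-fold higher number from compound 1 to compound 4 (1.07 log units; beyond the scatter), an at least 13-fold higher number from compound 2 to compound 4 (1.12 log units; beyond the scatter) and an at least 16-fold higher number from compound 3 to compound 4 (1.22 log units; beyond the scatter). The tolerance seen earlier therefore holds only among the groups that carry a six-membered aromatic ring of carbon, and carboxymethyl, with no ring, falls outside it.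

The compounds shown do not separate the loss of that ring from the arrival of the carboxylic acid; a plain alkyl chain, a methyl ester or an amide on this nitrogen would bear on that. They also leave open whether a benzoic acid, which keeps the ring alongside the acid, would stand with compound 1 or with compound 4.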